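A smaller side group on the shared core

A few compounds are considered here, and "the series" means these few. Any claim that something is new, unique, unknown or untested is made for them only; others in the source may bear on it.

Measured so far in an ADME assay on MT4 cells (Homo sapiens) for cytotoxicity, read by MTT assay (a higher number here means that more compound is tolerated, a lower number that less compound is tolerated), are three compounds
- compound 1 `Cc1ccc(CC2C(=O)N(O)C(=O)c3ccccc32)cc1` at 5500 nM
- compound 2 `CCCCCCC1C(=O)N(O)C(=O)c2ccccc21` at 4400 nM
- compound 3 `O=C1c2ccccc2C(Cc2ccccc2)C(=O)N1O` at 95000 nM

Compound 3 has the highest number of the three. Compound 4 `CC1C(=O)N(O)C(=O)c2ccccc21` differs from it by hydrogen in place of phenyl on a saturated chain carbon bound to a saturated ring carbon with hydrogen in place of phenyl on a saturated chain carbon bound to a saturated ring carbon. At that place, a 22-fold higher number from compound 2 to compound 3 (1.33 log units; beyond the scatter) is large, whereas a 1.3-fold lower number from compound 1 to compound 2 (0.10 log units; within the scatter) stays within the scatter. Elsewhere, a 17-fold higher number from compound 1 to compound 3 (1.24 log units; beyond the scatter) is also large. None of these steps removes phenyl, so in this assay no step beyond the scatter is expected, with a slight lean to a lower number. The estimate amounts to a 1.6-fold lower number from compound 3 to compound 4 (0.20 log units; within the scatter) as expected here. Compound 4 is estimated at 60000 nM (expected range 15000 nM to 200000 nM).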

Compound 4, half-maximal cytotoxic concentration: 250000 nM
Estimate against measurement, compound 4: 4.2-fold (0.62 log units) below, outside the stated range (above it).
By their numbers in this assay, from the lowest: compounds 2 and 1 (each within the scatter of the next); then compound 3; then compound 4.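

In this assay the step that takes phenyl away, a 2.6-fold higher number from compound 3 to compound 4 (0.42 log units; beyond the scatter), is modest, while the steps of a 57-fold higher number from compound 2 to compound 4 (1.75 log units; beyond the scatter) and a 45-fold higher number from compound 1 to compound 4 (1.66 log units; beyond the scatter) are large. At this place, on a saturated chain carbon bound to a saturated ring carbon, hydrogen thus gives the highest number of the four, and phenyl, though well above pentyl and 4-methylphenyl, stays short of it. Nothing at hand gives a reason for this order. The compounds shown leave open whether a side group carrying an amine or a carboxylic acid would keep the number as high as hydrogen does. They also leave open whether a propyl chain would fall nearer compound 4 or compound 2.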